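A Methyl Added to the Benzyl Ring of Compound 3

The source may hold more compounds than are shown below. What is called first, only, known or untested is meant among the compounds shown, and "the series" means these compounds.

Of the compounds shown here, three built on one shared core have been measured in a functional assay on HT-29 cells (Homo sapiens) for inhibition, read by MTT assay, with a stated time of 48 h; on this read-out higher numbers stand for weaker inhibition and lower numbers for stronger inhibition. Compound 1 `Cc1ccc(NC(=S)NC(=O)c2ccc(OCc3cccc(C(F)(F)F)c3)cc2)cc1-c1nc2ccccc2[nH]1` gives 8200 nM. Compound 2 `Cc1ccc(NC(=S)NC(=O)c2ccc(OCc3cccc(Cl)c3Cl)cc2)cc1-c1nc2ccccc2[nH]1` gives 63700 nM. Compound 3 `Cc1ccc(NC(=O)NC(=O)c2ccc(OCc3ccccc3)cc2)cc1-c1nc2ccccc2[nH]1` gives 16400 nM. Compound 3 stands second highest of the three numbers: its gap to compound 1 is within the scatter, while compound 2 lies beyond the scatter above it. Within the data shown here, compound 3 differs from compound 1 and from compound 2 in more than one place, so no single step links it to either.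

Compound 4 `Cc1ccc(COc2ccc(C(=O)NC(=O)Nc3ccc(C)c(-c4nc5ccccc5[nH]4)c3)cc2)cc1` has not yet been measured. It differs from compound 3 by methyl in place of hydrogen on an aromatic carbon. Among the measured compounds shown here, the only measured single-point step, a 7.8-fold higher number from compound 1 to compound 2 (0.89 log units; beyond the scatter), is a swap of one substituted benzyl ring for another and therefore bears on the step to compound 4 only loosely: it shows that changes on this ring can move the number, but no measured step adds a methyl group to it. For the measured compounds named here, with no direct precedent, compound 4 is expected to stay close to compound 3, a step of a 1.2-fold lower number from compound 3 to compound 4 (0.07 log units; within the scatter) that is expected to fall within the scatter. Compound 4 is therefore estimated at 14000 nM, with a range from 4500 nM to 45000 nM.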

Compound 4, half-maximal inhibitory concentration: 5110 nM
Compound 4: the middle estimate sits 2.7-fold (0.44 log units) above what was measured, within the range that was stated.
By their numbers in this assay, from the lowest: compounds 4, 1 and 3 (each within the scatter of the next, the first and the last beyond it); then compound 2.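

In this assay, among these compounds, a 3.2-fold lower number from compound 3 to compound 4 (0.51 log units; beyond the scatter) is the first measured step that adds a group to the benzyl ring rather than swapping one substituted ring for another. It shows that a single methyl in place of hydrogen, on an aromatic carbon para to a large group, is enough to move the number beyond the scatter, and that the move is towards stronger inhibition. The earlier step, a 7.8-fold higher number from compound 1 to compound 2 (0.89 log units; beyond the scatter), had shown only that one substituted ring can differ from another, whereas benzyl to 4-methylbenzyl shows that the smallest carbon addition counts at this place, though nothing shown here explains why.

The compounds shown leave open whether this gain is particular to methyl or would also appear with a chlorine, a methoxy group or an ethyl group on the same carbon. They also leave open whether a methyl at another carbon of this ring would move the number at all, and whether the same change would give a step of similar size in compounds that carry the thiocarbonyl of compound 1 instead of the carbonyl of compound 3.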